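A few compounds are considered here, and "the series" means these few. Any claim that something is new, unique, unknown or untested is made for them only; others in the source may bear on it.

Compound 1, `Nc1ccccc1NC(=O)c1ccc(CSC(=S)N2CCN(C(c3ccccc3)c3ccccc3)CC2)cc1`: 8%
Compound 2, `Nc1ccccc1NC(=O)c1ccc(CSC(=S)N2CCN(c3ccc(F)cc3)CC2)cc1`: 60.8%
Compound 3, `Nc1ccccc1NC(=O)c1ccc(CSC(=S)N2CCN(Cc3ccncc3)CC2)cc1`: 59.5%

In a functional assay on HeLa cells (Homo sapiens) for antiproliferative activity, read by CCK-8 assay, with a stated time of 72 h, tested at 2 uM (on this read-out lower numbers stand for a weaker effect and higher numbers for a stronger effect at the one concentration tested), compound 3 stands second highest of the three numbers. Its nearest neighbour is compound 2, which gives 60.8%; the step of a number 1.3 percentage points lower from compound 2 to compound 3 (within the scatter) lies within the scatter, so the two cannot be told apart. The furthest is compound 1, which gives 8%, a gap that is well beyond the scatter.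

Compound 4, `Nc1ccccc1NC(=O)c1ccc(CSC(=S)N2CCN(c3ccccc3F)CC2)cc1`, differs from compound 3 in one place: 2-fluorophenyl in place of (pyridin-4-yl)methyl on an amine nitrogen in a ring. Going by the values given here, the only measured step at this position is a number 1.3 percentage points lower from compound 2 to compound 3 (within the scatter), which exchanged a fluorophenyl group bound directly to the ring nitrogen for the (pyridin-4-yl)methyl group and produced no change beyond the scatter. Among the compounds with values here, compound 4 returns to a fluorophenyl group bound directly to that nitrogen, though a different fluorophenyl from that of compound 2, and no measured pair compares two such groups. The step from compound 3 to compound 4 is therefore expected to be small, a number 3.5 percentage points lower from compound 3 to compound 4 (within the scatter), with no direction beyond the scatter. Compound 4 is estimated at 56%, with a range from 35% to 75%.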

Compound 4, a percentage reported as inhibition, at one concentration (the size of the read-out at that concentration, not a potency): 17.5%
Compound 4: middle estimate off by 38.5 percentage points, on the high side; measured number below the stated range.
By their numbers in this assay, from the lowest: compounds 1 and 4 (each within the scatter of the next); then compounds 3 and 2 (each within the scatter of the next).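

In this assay, going by these compounds alone, the earlier compounds suggested that this ring nitrogen might tolerate quite different groups, but 2-fluorophenyl brings a number 42 percentage points lower from compound 3 to compound 4 (beyond the scatter). The closer comparison is a number 43.3 percentage points lower from compound 2 to compound 4 (beyond the scatter): 2-fluorophenyl and 4-fluorophenyl contain the same atoms and differ only in where the fluorine sits on the phenyl ring, so that placement alone separates these two results. Thus, having a fluorophenyl group on this nitrogen does not by itself preserve the read-out, and no available information explains the gap between these two isomers.

The compounds shown leave open whether the drop is specific to fluorine in the 2-fluorophenyl arrangement or extends to other groups, and plain phenyl, 3-fluorophenyl and 2-chlorophenyl on the same nitrogen would help separate those possibilities. Because each result comes from a single concentration, they also leave open how the potencies of these compounds compare across a range of concentrations.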